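A few compounds are considered here, and "the series" means these few. Any claim that something is new, unique, unknown or untested is made for them only; others in the source may bear on it.

Measured in an ADME assay on the whole organism (strain Sprague-Dawley) for metabolic stability, with Rattus norvegicus as the target; a higher number here means that the compound lasts longer, a lower number that the compound disappears faster:
- compound 1 `CN[C@@H](C)c1ccc(N2CC[C@H](NS(=O)(=O)c3ccc4cc(Cl)ccc4c3)C2=O)c(F)c1`: 18 h
- compound 2 `O=C1[C@@H](NS(=O)(=O)c2ccc3cc(Cl)ccc3c2)CCN1c1ccc(C2CCCN2)cc1F`: 9 h
- compound 3 `O=C1[C@@H](NS(=O)(=O)c2ccc3cc(Cl)ccc3c2)CCN1c1ccc([C@H]2CCCN2)cc1F`: 10.2 h

Compound 3 lies within the usual scatter of both other compounds, with a 1.8-fold lower number from compound 1 to compound 3 (0.25 log units; within the scatter) and a 1.1-fold higher number from compound 2 to compound 3 (0.05 log units; within the scatter). Compound 4 `O=C1[C@@H](NS(=O)(=O)c2ccc3cc(Cl)ccc3c2)CCN1c1ccc([C@@H]2CCCN2)cc1F` differs from compound 3 in one way: the two compounds have the same atoms and bonds and differ only in configuration as drawn: 1 of 2 stereo elements differ; a stereocentre at a saturated ring carbon is drawn R in compound 3 and S in compound 4. The first of those steps swaps a side group, so it says little about this change. The second touches the same stereocentre, and it is a 1.1-fold higher number from compound 2 to compound 3 (0.05 log units; within the scatter), where the only difference is the fact that one of compounds 2 and 3 is drawn with a defined configuration and the other without, at the place where they differ. On that small step, no change beyond the scatter is expected in this assay. The expected size is a 1.1-fold lower number from compound 3 to compound 4 (0.05 log units; within the scatter). Compound 4 is estimated at 9 h, with a range of 5 h to 16 h.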

Compound 4, half-life: 7.5 h
Beside the measured number, compound 4's estimate is 1.2-fold (0.08 log units) above it, within the range that was stated.
By their numbers in this assay, from the lowest: compounds 4, 2, 3 and 1 (each within the scatter of the next, the first and the last beyond it).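

In this assay, both drawn forms of the pyrrolidin-2-yl stereocentre can now be compared, and changing R to S gives a 1.4-fold lower number from compound 3 to compound 4 (0.13 log units; within the scatter), so configuration at this carbon shows no readable effect. The form drawn without a configuration fits this picture, with a 1.2-fold lower number from compound 2 to compound 4 (0.08 log units; within the scatter). Set against 1-(methylamino)ethyl, only the S form moves past the scatter, and modestly, with a 2.4-fold lower number from compound 1 to compound 4 (0.38 log units; beyond the scatter).

Going by these compounds, whether configuration would matter as little with a different ring, such as piperidin-2-yl in place of pyrrolidin-2-yl, stays open.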